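Extending the benzyl ring of compound 3

The source may hold more compounds than are shown below. What is called first, only, known or untested is meant among the compounds shown, and "the series" means these compounds.

Measured compounds:
Compound 1, `COC(=O)/C=C/c1cccc(N(Cc2ccc(/C=C/c3scnc3C)cc2)C(=O)C2CCCCC2)c1`, 227 nM
Compound 2, `COC(=O)/C=C/c1cccc(N(Cc2ccc(-c3ccc(F)c(Cl)c3)cc2)C(=O)C2CCCCC2)c1`, 66 nM
Compound 3, `COC(=O)/C=C/c1cccc(N(Cc2ccccc2)C(=O)C2CCCCC2)c1`, a limit only

All three compounds were tested in an assay on isolated protein with Bile acid receptor (Homo sapiens) as the target; a lower number here means that less compound is needed, a higher number that more compound is needed for the effect. Compound 1 gives 227 nM and compound 2 gives 66 nM. For compound 3 the assay reports only a limit, > 1000 nM, which is not a measured number (the limit of > 1000 nM in this assay, at which 1 of the 3 values shown sits). Compound 3 therefore stands at the weak end of the three, with no exact value known.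

Compound 4, `COC(=O)/C=C/c1cccc(N(Cc2ccc(/C=C/C(=O)OCc3ccccc3)cc2)C(=O)C2CCCCC2)c1`, has not yet been measured. It differs from compound 3 by one change: 2-(benzyloxycarbonyl)ethenyl in place of hydrogen on an aromatic carbon.

For the measured compounds named here, two measured steps bear on this change, both ending at the same unsubstituted position of compound 3. Removing the substituent at this position gave an at least 4.4-fold higher number from compound 1 to compound 3 (0.64 log units; beyond the scatter), and removing a different substituent there gave an at least 15-fold higher number from compound 2 to compound 3 (1.18 log units; beyond the scatter). Placing a substituent on this carbon has thus, in both cases, been linked to a lower number, and the change in compound 4 adds a group of comparable extent. A step toward a lower number, beyond the scatter, is therefore expected for compound 4 in this assay, on the order of an at least 4.5-fold lower number from compound 3 to compound 4 (0.65 log units; beyond the scatter). Compound 4 is estimated at 220 nM, within a range from 60 nM to 800 nM.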

Compound 4, half-maximal effective concentration: > 1000 nM
Compound 4 gave a limit, no number (the forecaster's own chance of this, stated with the estimate: 15%); middle value at least 4.5-fold (0.65 log units) from the limit.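

Compound 3 and compound 4 both sit at a limit of this assay, not at measured numbers, so the step between them cannot be read: the limit of > 1000 nM in this assay, at which 2 of the 4 values shown sit.

Even so, a substituent on this aromatic carbon, para to a large group, no longer goes with a low number in every case, and compound 4 goes against the trend set by compound 1 and compound 2. Exchanging the whole substituent gives an at least 15-fold higher number from compound 2 to compound 4 (1.18 log units; beyond the scatter), with 2-(benzyloxycarbonyl)ethenyl in place of 3-chloro-4-fluorophenyl, while changing only the end of the ethenyl chain gives an at least 4.4-fold higher number from compound 1 to compound 4 (0.64 log units; beyond the scatter), with benzyloxycarbonyl in place of 4-methyl-1,3-thiazol-5-yl. The ethenyl chain is thus not enough on its own, and the group at its far end makes a difference beyond the scatter.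

From the compounds shown here alone, how far compound 4 lies beyond its limit, and whether it differs at all from compound 3, remains unknown. Also open, going by these compounds, is whether a carboxylic acid, a methyl ester or an amide at the end of the ethenyl chain would give a number near that of compound 1 or would also end at the limit.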